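Swapping Methyl for Methoxy on a Pyridyl Urea

This account rests on a few compounds, and the source may have more. Where it says the series, first, only, none or still open, it means among the compounds named here.

Measured so far:
compound 1 `COc1cc(C)nc(OC)c1NC(=O)N(Cc1ccc(Oc2ccc(F)cc2)cc1)C1CCCCCC1`: 33 nM
compound 2 `Cc1cc(C)c(NC(=O)N(Cc2ccc(Oc3ccc(F)cc3)cc2)C2CCCCCC2)c(C)n1`: 62 nM

In an assay for inhibition of acyl-CoA:cholesterol acyltransferase (Oryctolagus cuniculus), using microsomes (on this read-out lower numbers stand for stronger inhibition and higher numbers for weaker inhibition), compound 1 gives 33 nM and compound 2 gives 62 nM. Among the compounds with values here, compound 2 has the highest of the two numbers, but the only step between them, a 1.9-fold higher number from compound 1 to compound 2 (0.27 log units; within the scatter), is small enough that the two compounds cannot be ranked against each other.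

Compound 3 `COc1nc(C)ccc1NC(=O)N(Cc1ccc(Oc2ccc(F)cc2)cc1)C1CCCCCC1` differs from compound 2 in one place: 2-methoxy-6-methylpyridin-3-yl in place of 2,4,6-trimethylpyridin-3-yl on an amide-type nitrogen. Within the data shown here, the one measured step bearing on this is a 1.9-fold higher number from compound 1 to compound 2 (0.27 log units; within the scatter), where methoxy groups replaced methyl groups on the same ring and the number moved only a little. Compound 3 sits between the two measured compounds in its pattern of methyl and methoxy groups, so no step beyond the scatter is expected in this assay, with the number estimated to be a 1.4-fold lower number from compound 2 to compound 3 (0.14 log units; within the scatter).

Compound 3 is therefore expected to give about 45 nM, somewhere between 15 nM and 135 nM.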

Compound 3, half-maximal inhibitory concentration: 39 nM
Compound 3: the middle estimate sits 1.2-fold (0.06 log units) above what was measured, within the range that was stated.
By their numbers in this assay, from the lowest: compounds 1, 3 and 2 (each within the scatter of the next).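

In this assay, 2-methoxy-6-methylpyridin-3-yl in place of 2,4,6-trimethylpyridin-3-yl on an amide-type nitrogen gives a 1.6-fold lower number from compound 2 to compound 3 (0.20 log units; within the scatter) and so does not separate these two compounds. Hydrogen in place of methoxy on an aromatic carbon gives a 1.2-fold higher number from compound 1 to compound 3 (0.07 log units; within the scatter) and shows that removing this one methoxy group from compound 1 produces no step beyond the scatter. Together, these two new steps show that each of these single changes on the ring leaves the number within the scatter, and no supporting measurement is available to explain this result.

All three compounds carry only methyl, methoxy or hydrogen at the places that vary on this ring. As far as these compounds go, whether an ethoxy group, a dimethylamino group or a chlorine atom in place of methoxy would keep the number in this range remains open.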